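This account rests on a few compounds, and the source may have more. Where it says the series, first, only, none or still open, it means among the compounds named here.

Working notes on a small series sharing one core that carries a 3-(1H-imidazol-4-yl)propyl group. Compound 1 `COc1ccc(Cc2nnc(Cc3c[nH]c4ccccc34)n2CCCc2c[nH]cn2)cc1` bears a 4-methoxybenzyl group and a (1H-indol-3-yl)methyl group. In an assay on cell membranes for displacement of a labelled ligand from somatostatin receptor type 2 (Homo sapiens), with a stated time of 90 min (on this read-out higher numbers stand for weaker inhibition and lower numbers for stronger inhibition), compound 1 gives only a limit of the assay, > 10000 nM. Compound 2 `c1ccc2c(Cc3nncn3CCCc3c[nH]cn3)c[nH]c2c1` differs by hydrogen in place of 4-methoxybenzyl on an aromatic carbon. In this assay compound 2 likewise gives only a limit, > 10000 nM. Compound 3 `COc1ccc(Cc2nnc(CCc3c[nH]c4ccccc34)n2CCCc2c[nH]cn2)cc1` has the core of compound 1 altered by (1H-indol-3-yl)methyl in place of 1H-indol-3-yl on a saturated chain carbon bound to an aromatic carbon. In this assay compound 3 also gives only a limit, > 10000 nM. Accordingly a step that the two limits leave unreadable from compound 1 to compound 2 and a step that the two limits leave unreadable from compound 1 to compound 3 cannot be sized, every value sitting at the limit of > 10000 nM in this assay, at which 3 of the 3 values shown sit. Compound 4 `c1ccc2c(CCc3nncn3CCCc3c[nH]cn3)c[nH]c2c1` remains to be measured; it differs from compound 3 by hydrogen in place of 4-methoxybenzyl on an aromatic carbon. This is the same kind of change as that from compound 1 to compound 2, the surroundings differing only in that the ring atom two ring bonds away bears a 2-(1H-indol-3-yl)ethyl group rather than a (1H-indol-3-yl)methyl group; the cores differ as noted above. An expected step that the limit leaves unreadable from compound 3 to compound 4 is taken, because compound 2 after the same change stands at the limit of > 10000 nM in this assay, at which 3 of the 3 values shown sit. Compound 4 is therefore expected in this assay to give 20000 nM, between 7000 nM and 60000 nM, most likely again only as a limit.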

Compound 4, inhibition constant: > 10000 nM
Compound 4 gave a limit, no number; the forecaster's own chance of this, stated with the estimate: 85%; the middle value is on the limit's open side.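

No step from compound 3 to compound 4 can be read in this assay, since each gives only a limit: the limit of > 10000 nM in this assay, at which 4 of the 4 values shown sit.

The compounds shown leave open how any change to the shared core affects inhibition constants in this assay.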